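Chloro to cyano on the aryl piperazine of compound 1

The compounds below may be only part of what the source reports. "The series", "measured", "known", "first", "only" and "open" are said of these compounds alone.

Compound 1 `Nc1ccccc1NC(=O)c1ccc(CSC(=S)N2CCN(c3ccc(Cl)cc3)CC2)cc1` gives 29% in a functional assay on A-375 cells (Homo sapiens) for antiproliferative activity, read by CCK-8 assay, with a stated time of 72 h, tested at 8 uM (on this read-out lower numbers stand for a weaker effect and higher numbers for a stronger effect at the one concentration tested), and stands lowest of the three numbers shown. Compound 2 `Nc1ccccc1NC(=O)c1ccc(CSC(=S)N2CCc3ccc([N+](=O)[O-])cc32)cc1` gives 42% in this assay, a reading beyond the scatter above compound 1. Compound 3 `CN(Cc1cccnc1)C(=S)SCc1ccc(C(=O)Nc2ccccc2N)cc1` gives 83.8% in this assay, far beyond the scatter above compound 1. No pair among these three differs in one place, so no step is available to rest on.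

Compound 4 `N#Cc1ccc(N2CCN(C(=S)SCc3ccc(C(=O)Nc4ccccc4N)cc3)CC2)cc1` differs from compound 1 in one place: cyano in place of chloro on an aromatic carbon. Nothing among the three measured compounds speaks for a change beyond the scatter from such a swap, so compound 4 is expected near compound 1, with a step of a number 4 percentage points higher from compound 1 to compound 4 (within the scatter) not expected to exceed the scatter. Compound 4 is estimated at 33%, within 15% to 58%.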

Compound 4, a percentage reported as inhibition, at one concentration (the size of the read-out at that concentration, not a potency): 62.9%
For compound 4 the middle estimate is 29.9 percentage points below the measured one, outside the stated range (above it).
By their numbers in this assay, from the lowest: compound 1; then compound 2; then compound 4; then compound 3.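

Cyano in place of chloro on this aromatic carbon, para to a large group, gives a number 33.9 percentage points higher from compound 1 to compound 4 (beyond the scatter) in this assay. Among the compounds shown here, this is the only single-place step so far, and it shows that the substituent at this position alone can move the read-out at the one concentration tested, with the rest of compound 1 unchanged. Nothing available accounts for the size of this step. From the compounds shown here alone, whether a methoxy group, an amine or a carboxylic acid at this carbon would give a similar step remains open. One pair also cannot show whether the same swap would carry over to other parts of the series.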